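Methylsulfonyl for Isopropoxy: Cytotoxicity Outlook for Compound 4

This account rests on a few compounds, and the source may have more. Where it says the series, first, only, none or still open, it means among the compounds named here.

Compound 1, `CC(C)Oc1cccc(-c2ccc(C(=O)N(Cc3cccc(OCCCCCC(=O)O)c3)C(C)C)cc2)c1`: > 26000 nM
Compound 2, `CC(C)N(Cc1cccc(OCCCCCC(=O)O)c1)C(=O)c1ccc(-c2cccc(O)c2)cc1`: > 26000 nM
Compound 3, `COc1cc(F)cc(-c2ccc(C(=O)N(Cc3cccc(OCCCCCC(=O)O)c3)C(C)C)cc2)c1`: > 26000 nM

In an ADME assay on HEK293 cells (Homo sapiens) for cytotoxicity, read by CellTiter-Glo and resazurin assay, with a stated time of 72 h (a lower number here means that less compound is needed, a higher number that more compound is needed for the effect), compound 1 reaches only a limit of the assay. Compound 2 likewise reports only a limit. Compound 3 also reports only a limit, so that the limit of > 26000 nM in this assay, at which 3 of the 3 values shown sit, gathers every measured value. The steps a step that the two limits leave unreadable from compound 1 to compound 2, a step that the two limits leave unreadable from compound 1 to compound 3 and a step that the two limits leave unreadable from compound 2 to compound 3 are accordingly unreadable in size. Compound 4, `CC(C)N(Cc1cccc(OCCCCCC(=O)O)c1)C(=O)c1ccc(-c2cccc(S(C)(=O)=O)c2)cc1`, differs from compound 1 by methylsulfonyl in place of isopropoxy on an aromatic carbon, the 3-isopropoxyphenyl becoming 3-(methylsulfonyl)phenyl. The measured steps alter the same group yet give no readable size, so nothing points to a step beyond the scatter. Compound 4 is therefore expected to show a step that the limit leaves unreadable from compound 1 to compound 4 and most likely to report a limit again. The estimate for compound 4 is 40000 nM, between 20000 nM and 100000 nM.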

Compound 4, half-maximal effective concentration: > 26000 nM
Compound 4: a limit, no number (the forecaster's own chance of this, stated with the estimate: 90%); the middle value is on the limit's open side.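

Compound 4 gives the limit > 26000 nM in this assay and so its steps from compound 1, compound 2 and compound 3 cannot be read in size. The compounds shown leave open what concentration any of them needs for the half-maximal effect.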